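Swapping Chloro for tert-Butyl on a Shared Core

The compounds below may be only part of what the source reports. "The series", "measured", "known", "first", "only" and "open" are said of these compounds alone.

Compound 1 `COc1cccc(CNCCCNc2ccnc3cc(Oc4ccc(Cl)cc4)ccc23)c1O` was tested in an ADME assay on HepG2 cells (Homo sapiens) for cytotoxicity, read by luminescence, CellTiter-Glo and ATP content, with a stated time of 72 h (on this read-out lower numbers stand for an effect already at smaller amounts and higher numbers for an effect only at larger amounts of compound), where compound 1 gives 5700 nM. Among the three compounds measured so far, this is the second highest number: compound 2 `COc1cccc(Oc2ccc3c(NCCCNCc4cc(F)ccc4OC)ccnc3c2)c1` gives 7100 nM, and compound 3 `CC(C)(C)c1ccc(-c2ccc3c(NCCCNCc4ccco4)ccnc3c2)cc1` gives 3150 nM. Both of these lie within the scatter of compound 1, so no order among the three can be read from them. Compound 4 `COc1cccc(CNCCCNc2ccnc3cc(Oc4ccc(C(C)(C)C)cc4)ccc23)c1O` has not yet been measured. It differs from compound 1 in one place: tert-butyl in place of chloro on an aromatic carbon. Going by the values given here, no measured pair shows this kind of change. The step is expected to be small, leaning slightly toward a lower number but not clearly beyond the scatter, an estimated 1.4-fold lower number from compound 1 to compound 4 (0.13 log units; within the scatter). Compound 4 is therefore expected to give about 4200 nM, with a likely range from 1900 nM to 9500 nM.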

Compound 4, half-maximal effective concentration: 1500 nM
For compound 4 the middle estimate is 2.8-fold (0.45 log units) above the measured one; the measured number lies below the stated range.
By their numbers in this assay, from the lowest: compound 4; then compounds 3, 1 and 2 (each within the scatter of the next, the first and the last beyond it).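

Putting tert-butyl in place of chloro on the phenoxy group gives a 3.8-fold lower number from compound 1 to compound 4 (0.58 log units; beyond the scatter) and this lies beyond the scatter, so the group at this place does affect the number in this assay. This single-place change separates two compounds clearly, which the earlier numbers, all within the scatter of compound 1, could not do. Nothing at hand explains the step.

Only chloro and tert-butyl are shown at this place, so how an amine or a carboxylic acid there would read stays open. As far as these compounds go, whether the same swap gives a similar step on another core also remains unknown.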